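Moving the methyl around the phenyl on the triazole

The source may hold more compounds than are shown below. What is called first, only, known or untested is meant among the compounds shown, and "the series" means these compounds.

Measured so far, all in a functional assay on A549 cells (Homo sapiens) for antiproliferative activity, read by MTT assay, with a stated time of 24 h; a lower number here means a stronger inhibitor, a higher number a weaker inhibitor:
compound 1, `O=c1[nH]cc(S(=O)(=O)Nc2cccc(-c3cn(-c4ccccc4)nn3)c2)c(=O)[nH]1`, gives 12700 nM.
compound 2, `Cc1ccccc1-n1cc(-c2cccc(NS(=O)(=O)c3c[nH]c(=O)[nH]c3=O)c2)nn1`, gives 5470 nM.
compound 3, `Cc1cccc(-n2cc(-c3cccc(NS(=O)(=O)c4c[nH]c(=O)[nH]c4=O)c3)nn2)c1`, gives 3550 nM.

Compound 3 has the lowest number of the three in this assay. Its gap to compound 1 is beyond the scatter, but its gap to compound 2 is within the scatter, so compound 2 and compound 3 cannot be told apart on these numbers.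

The next compound, compound 4, `Cc1ccc(-n2cc(-c3cccc(NS(=O)(=O)c4c[nH]c(=O)[nH]c4=O)c3)nn2)cc1`, differs from compound 3 in one place: 4-methylphenyl in place of 3-methylphenyl on an aromatic nitrogen.

Going by the values given here, two measured steps bear on this. Putting a methyl onto the phenyl at all gave a 2.3-fold lower number from compound 1 to compound 2 (0.37 log units; beyond the scatter) and a 3.6-fold lower number from compound 1 to compound 3 (0.55 log units; beyond the scatter), both modest. Moving that methyl from one ring position to another gave a 1.5-fold lower number from compound 2 to compound 3 (0.19 log units; within the scatter), which is within the scatter. The change to compound 4 is again a move of the methyl, not its addition or removal, so no step beyond the scatter is expected; the estimated step is a 1.1-fold lower number from compound 3 to compound 4 (0.05 log units; within the scatter).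

For compound 4 the expected value in this assay is 3200 nM, within a range of 1300 nM to 8000 nM.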

Compound 4, half-maximal inhibitory concentration: 3630 nM
Beside the measured number, compound 4's estimate is 1.1-fold (0.05 log units) below it; low and high end bracket the measured number.
By their numbers in this assay, from the lowest: compounds 3, 4 and 2 (each within the scatter of the next); then compound 1.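

In this assay, compound 4 adds the 4-methylphenyl group to the 2-methylphenyl and 3-methylphenyl groups already seen on the aromatic nitrogen, and the new data give no sign that the placement of the methyl on this phenyl matters: the two steps to compound 4 are (a 1.0-fold higher number from compound 3 to compound 4 (0.01 log units; within the scatter)) and (a 1.5-fold lower number from compound 2 to compound 4 (0.18 log units; within the scatter)), and each lies within the scatter. The only readable change in this small set is still the step from the unsubstituted phenyl to a methylphenyl, now seen for a third placement (a 3.5-fold lower number from compound 1 to compound 4 (0.54 log units; beyond the scatter)), and no compound shown goes against it, though this step remains modest. No supporting information is available to explain why the three methylphenyl compounds cannot be told apart.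

The compounds shown leave open whether this flat response is particular to methyl, since a methoxy group, a chlorine atom, an ethyl group or a carboxylic acid on the same phenyl could give a different result. They also leave open how far the numbers can move at this position, given that all of them sit in the micromolar range of this single cell assay.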